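The compounds below may be only part of what the source reports. "The series", "measured", "known", "first", "only" and "open" are said of these compounds alone.

Measured compounds:
Compound 1 `CCCNC(=O)c1cc(-n2cc(-c3cc(F)cc(F)c3)nn2)ccc1O` — in a functional assay on RAW264.7 cells (Mus musculus) for inhibition, read by Griess assay, with a stated time of 20 h (a lower number here means a stronger inhibitor, a higher number a weaker inhibitor), compound 1 gives > 20000 nM, which is a limit of the assay.
Compound 2 `O=C(c1cc(-n2cc(-c3cc(F)cc(F)c3)nn2)ccc1O)N1CCCCC1` — in this assay compound 2 gives > 20000 nM, again a limit.
Compound 3 `CCCNC(=O)c1ccc(-n2cc(-c3ccccc3)nn2)cc1O` — in this assay compound 3 gives > 20000 nM, also a limit.

Compound 4 `O=C(c1ccc(-n2cc(-c3ccccc3)nn2)cc1O)N1CCCCC1` has not yet been measured. The change from compound 3 to compound 4 is piperidin-1-yl in place of propylamino on a carbonyl carbon. The same change is made from compound 1 to compound 2, (piperidin-1-yl in place of propylamino on a carbonyl carbon), and the step it made there is a step that the two limits leave unreadable from compound 1 to compound 2. How the core of compound 3 differs from the core of compound 1 is not broken down here. Going by the values given here, all values so far sit at the limit of > 20000 nM in this assay, at which 3 of the 3 values shown sit. Compound 4 is expected to show a step that the limit leaves unreadable from compound 3 to compound 4. This rests on the measured step that the two limits leave unreadable from compound 1 to compound 2 and on the limit at which compound 3 sits, > 20000 nM. Compound 4 is therefore estimated at 30000 nM in this assay, most probably reported again only as a limit.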

Compound 4, half-maximal inhibitory concentration: > 20000 nM
Compound 4 gave a limit, no number (the forecaster's own chance of this, stated with the estimate: 85%); the middle value is on the limit's open side.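

Compound 3 and compound 4 both stand only as limits, so no step can be read between them: the limit of > 20000 nM in this assay, at which 4 of the 4 values shown sit. The compounds shown leave open what potency lies past that limit, and whether exchanging propylamino for piperidin-1-yl changes it at all.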